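The compounds below may be only part of what the source reports. "The series", "measured", "known", "first", "only" and "open" are said of these compounds alone.

Compound 1 `CCCCNc1nc(N)nc2c1CN(Cc1ccccc1)CC2`: 0.06 uM
Compound 2 `CCCCNc1nc(N)nc2c1CN(Cc1ccccc1Cl)CC2`: 0.05 uM

In an assay on HEK293 cells for agonist activity at Toll-like receptor 8 (Homo sapiens), read by a luciferase reporter, with a stated time of 6 h (on this read-out lower numbers stand for an effect already at smaller amounts and higher numbers for an effect only at larger amounts of compound), compound 1 gives 0.06 uM and compound 2 gives 0.05 uM. The step of a 1.2-fold lower number from compound 1 to compound 2 (0.08 log units; within the scatter) stays within the scatter, so compound 2 and compound 1 sit within the scatter of each other and neither stands apart on this assay. Compound 3 `CCCCNc1nc(N)nc2c1CN(Cc1cccc(OC)c1Cl)CC2` differs from compound 2 in one place: methoxy in place of hydrogen on an aromatic carbon. Among the compounds with values here, the only measured step that bears on this change is a 1.2-fold lower number from compound 1 to compound 2 (0.08 log units; within the scatter), which also altered the same aromatic ring and produced no movement beyond the scatter; no measured step adds a methoxy, so the data give no direction for the new group. Compound 3 is therefore expected to show a step of no change at the digits printed from compound 2 to compound 3 (within the scatter) in this assay, that is, none beyond the scatter. The estimate for compound 3 is 0.05 uM, within a range of 0.015 uM to 0.15 uM.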

Compound 3, minimum effective concentration: 0.04 uM
Compound 3: the middle estimate sits 1.3-fold (0.10 log units) above what was measured, within the range that was stated.
By their numbers in this assay, from the lowest: compounds 3, 2 and 1 (each within the scatter of the next).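

On the aromatic ring that already carries the chloro group, a methoxy group can stand ortho to that chloro group and meta to a large group with no movement beyond the scatter in this assay, as the step shows: a 1.3-fold lower number from compound 2 to compound 3 (0.10 log units; within the scatter). Compound 1 and compound 2 had shown this only for a chloro group in place of hydrogen, whereas compound 3 extends it to an entering group of 2 heavy atoms with 1 hydrogen-bond acceptor. Nothing measured here speaks to any reason for this outcome.

From the compounds shown here alone, it remains open whether an amine, a carboxylic acid or a longer alkoxy chain at this place would also stay within the scatter. Also open, going by these compounds, is whether methoxy would behave the same way without the chloro group.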